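Tetrazole aryl substituent: pyridinyl to trifluoromethylphenyl

The source may report more compounds than this note shows. Statements on the series, on what has been measured and on what is new or still open speak of the compounds shown alone.

Three compounds of this series have numbers in an assay on HEK293 cells for activation of Kir3.1/Kir3.2 (Homo sapiens), read by thallium flux; on this read-out higher numbers stand for an effect only at larger amounts of compound and lower numbers for an effect already at smaller amounts. Compound 1 `CC1CC1c1cc(NC(=O)Cn2nnc(-c3ccccc3)n2)n(C2CCCCC2)n1` gives 843 nM. Compound 2 `Cc1cc(NC(=O)Cn2nnc(-c3ccccc3)n2)n(CC2CCCCC2)n1` gives 176 nM. Compound 3 `Cc1cc(NC(=O)Cn2nnc(-c3ccccn3)n2)n(C2CCCCC2)n1` gives 14600 nM and stands highest of the three: the nearest number, that of compound 1, is lower by a margin beyond the scatter, and the furthest, that of compound 2, lies still further below. Compounds 1 and 2 each carry a six-membered aromatic ring of carbon only on the five-membered aromatic ring with 4 nitrogen, whereas compound 3 carries pyridin-2-yl there.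

Compound 4 `Cc1cc(NC(=O)Cn2nnc(-c3cccc(C(F)(F)F)c3)n2)n(C2CCCCC2)n1` has not yet been measured. It differs from compound 3 in one place: 3-(trifluoromethyl)phenyl in place of pyridin-2-yl on an aromatic carbon. Among the measured compounds shown here, no measured pair shows this exact change. Going back to a ring of carbon only in that place, the number is expected to fall well beyond the scatter, because compound 1 gives 843 nM and compound 2 gives 176 nM with such a ring. The estimated step is a 24-fold lower number from compound 3 to compound 4 (1.39 log units; beyond the scatter). Compound 4 is expected to give about 600 nM, within a range from 120 nM to 3000 nM.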

Compound 4, half-maximal effective concentration: 183 nM
Compound 4: middle estimate off by 3.3-fold (0.52 log units), on the high side; low and high end bracket the measured number.
By their numbers in this assay, from the lowest: compounds 2 and 4 (each within the scatter of the next); then compound 1; then compound 3.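

In this assay, among the compounds shown here, 3-(trifluoromethyl)phenyl in place of pyridin-2-yl on the aromatic carbon of the five-membered aromatic ring with 4 nitrogen gives an 80-fold lower number from compound 3 to compound 4 (1.90 log units; beyond the scatter) and provides the first comparison at this position with the rest of the structure unchanged. This large step, beyond the scatter, shows that the group at this position alone can move the number substantially on the shared core. Nothing measured here accounts for the step.

The change removes the pyridine ring nitrogen and adds trifluoromethyl in a single step, and the compounds shown do not separate these two parts; unsubstituted phenyl on the same core would do so. Also open, from the compounds shown here alone, is how a methoxy group or a chlorine atom in place of trifluoromethyl would compare.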